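This account rests on a few compounds, and the source may have more. Where it says the series, first, only, none or still open, it means among the compounds named here.

Compound 1, `N[C@@H](COP(=O)(O)OCCCOC(=O)CCc1ccccc1OCCCCOc1ccccc1)C(=O)O` — in an assay on cells for activation of probable G-protein coupled receptor 34 (Mus musculus), with a stated time of 1 h (a lower number here means a smaller maximal response, a higher number a larger maximal response), compound 1 gives 0.033.
Compound 2, `N[C@@H](COP(=O)(O)OCCCOC(=O)CCc1ccccc1OCc1cccc(OC2CCCCC2)c1)C(=O)O` — compound 2 gives 0.11.
Compound 3, `N[C@@H](COP(=O)(O)OCCCOC(=O)CCc1ccccc1OCc1cccc(Oc2cccc(Cl)c2)c1)C(=O)O` — compound 3 gives 0.53.

Compound 3 stands highest of the three, with compound 2 nearest and compound 1 furthest below it. Going by the values given here, the one single-point step that has been measured, a number 0.42 higher from compound 2 to compound 3 (beyond the scatter), is large, and it shows that what sits on that oxygen on the aromatic ring carries much of the response here.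

Compound 4, `N#Cc1ccc(Oc2cccc(COc3ccccc3CCC(=O)OCCCOP(=O)(O)OC[C@H](N)C(=O)O)c2)cc1`, is the next step from compound 3: 4-cyanophenyl in place of 3-chlorophenyl on an oxygen on an aromatic ring. Among the compounds with values here, no measured step exchanges one substituted phenyl for another on this oxygen, so the only guide is that an aromatic ring is kept in the place where the large step into compound 3 put one. A moderate change in either direction cannot be ruled out, but no step beyond the scatter is expected. Compound 4 is therefore estimated at 0.45, between 0.2 and 0.7, an expected step of a number 0.080 lower from compound 3 to compound 4 (within the scatter).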

Compound 4, intrinsic activity: the largest response reached, as a fraction of the reference agonist's: 0.041
Compound 4: the middle estimate sits 0.41 above what was measured; measured number below the stated range.
By their numbers in this assay, from the lowest: compounds 1, 4 and 2 (each within the scatter of the next); then compound 3.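

In this assay, the change with a number 0.49 lower from compound 3 to compound 4 (beyond the scatter) shows that an aromatic ring on this oxygen does not by itself carry the response, which the step into compound 3 alone could not show. With a number 0.069 lower from compound 2 to compound 4 (within the scatter), the 4-cyanophenyl and cyclohexyl groups cannot be told apart here, so the high response belongs, among these groups, to the 3-chlorophenyl group and not to aromatic rings on this oxygen in general. No measurement at hand accounts for this loss of response.

The 3-chlorophenyl and 4-cyanophenyl groups differ both in the group on the ring and in where it sits, so the compounds shown cannot separate these two changes; 4-chlorophenyl and 3-cyanophenyl groups would do so. Going by these compounds, whether an unsubstituted phenyl on this oxygen keeps the response also remains open.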